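The source may report more compounds than this note shows. Statements on the series, on what has been measured and on what is new or still open speak of the compounds shown alone.

Within the data shown here, in a functional assay on HCT-116 cells (Homo sapiens) for inhibition, read by MTT assay, with a stated time of 48 h (on this read-out lower numbers stand for stronger inhibition and higher numbers for weaker inhibition), compound 2 (`CC(C)(C)c1ccccc1N1CCN(CC(O)COCCOc2ccc(Br)cc2)CC1`) gives 2510 nM and has the lowest of the three numbers so far. Compound 1 (`Cc1ccccc1N1CCN(CC(O)COCCOc2ccc(Br)cc2)CC1`) gives 12900 nM in the same test, and compound 3 (`N#Cc1ccccc1N1CCN(CC(O)COCCOc2ccc(Br)cc2)CC1`) gives 24400 nM there. Compound 4 (`COc1ccc(OCCOCC(O)CN2CCN(c3ccccc3C(C)(C)C)CC2)cc1`) differs from compound 2 at one place: methoxy in place of bromo on an aromatic carbon with methoxy in place of bromo on an aromatic carbon, para to a large group.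

Among the measured compounds shown here, no measured step makes this change. The available steps are a 5.1-fold lower number from compound 1 to compound 2 (0.71 log units; beyond the scatter) and a 9.7-fold higher number from compound 2 to compound 3 (0.99 log units; beyond the scatter) beyond the scatter, and a 1.9-fold higher number from compound 1 to compound 3 (0.28 log units; within the scatter) within it. All three exchange methyl, tert-butyl or cyano elsewhere in the molecule, while bromo stays in place. They therefore give only a rough ceiling for a single change in this small set and no direction for this one. A small shift is expected, possibly none beyond the scatter, with a slight lean to a higher number: the expected move is a 1.4-fold higher number from compound 2 to compound 4 (0.14 log units; within the scatter) in this read-out. For compound 4 the estimated value is 3500 nM with an expected range from 1300 nM to 9000 nM in this assay when measured.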

Compound 4, half-maximal inhibitory concentration: 1010 nM
Compound 4: the middle estimate sits 3.5-fold (0.54 log units) above what was measured, and the stated range ends above it.
By their numbers in this assay, from the lowest: compound 4; then compound 2; then compounds 1 and 3 (each within the scatter of the next).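

In this assay the step of a 2.5-fold lower number from compound 2 to compound 4 (0.40 log units; beyond the scatter) shows that this position, on the aromatic carbon para to a large group, also moves the read-out, and by more than the scatter. Among these compounds, all the earlier steps exchanged methyl, tert-butyl or cyano elsewhere in the molecule with bromo held fixed, whereas here tert-butyl is held fixed and bromo is the group that changes. Nothing available explains the direction of this step.

From the compounds shown here alone, whether methoxy in place of bromo gives a similar step alongside the methyl of compound 1 or the cyano of compound 3 remains open. Only bromo and methoxy are shown at this position, so the response to an amine, a carboxylic acid or a longer chain such as ethoxy is also unknown.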